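Swapping a nitro for two chlorines on the aryl ring

The source may hold more compounds than are shown below. What is called first, only, known or untested is meant among the compounds shown, and "the series" means these compounds.

Measured compounds and their values:
- compound 1, `O=C(COc1ccc(C(=O)/C=C/c2cccc(Br)c2)cc1)N[C@H]1CCOC1=O`: 7890 nM
- compound 2, `O=C(COc1ccc(C(=O)/C=C/c2cccc(F)c2)cc1)N[C@H]1CCOC1=O`: 23200 nM
- compound 3, `O=C(COc1ccc(C(=O)/C=C/c2cccc([N+](=O)[O-])c2)cc1)N[C@H]1CCOC1=O`: 56300 nM

All three share one core and differ only in the group on the aromatic ring at the end of the double-bonded chain. In a functional assay on PC-3 cells (Homo sapiens) for antiproliferative activity, read by MTT assay, with a stated time of 72 h (a lower number here means a stronger inhibitor, a higher number a weaker inhibitor), compound 3 gives the highest of the three numbers, that is, it is the weakest of the three: the nearest is compound 2, and the gap is shown by a 2.4-fold higher number from compound 2 to compound 3 (0.39 log units; beyond the scatter), while the gap to compound 1 is shown by a 7.1-fold higher number from compound 1 to compound 3 (0.85 log units; beyond the scatter).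

Compound 4, `O=C(COc1ccc(C(=O)/C=C/c2ccc(Cl)cc2Cl)cc1)N[C@H]1CCOC1=O`, has not yet been measured. It differs from compound 3 by 2,4-dichlorophenyl in place of 3-nitrophenyl on a double-bonded chain carbon bound to a double-bonded chain carbon.

Within the data shown here, the steps that bear on this are the two that end at the nitro compound: a 7.1-fold higher number from compound 1 to compound 3 (0.85 log units; beyond the scatter) and a 2.4-fold higher number from compound 2 to compound 3 (0.39 log units; beyond the scatter). Both show that replacing bromo or fluoro with nitro raised the number; undoing the nitro should therefore lower it, and two chlorines are closer in kind to bromo than to fluoro, so a step toward the value of compound 1 seems plausible. The change here also moves the ring pattern, so the match is not exact.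

Compound 4 is therefore expected to give roughly 9000 nM in this assay, within 3000 nM to 27000 nM, which means an expected step of a 6.3-fold lower number from compound 3 to compound 4 (0.80 log units; beyond the scatter) from compound 3.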

Compound 4, half-maximal inhibitory concentration: 8040 nM
The estimate for compound 4 lay 1.1-fold (0.05 log units) above the measured number; the range from low to high includes it.
By their numbers in this assay, from the lowest: compounds 1 and 4 (each within the scatter of the next); then compound 2; then compound 3.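

In this assay, 2,4-dichlorophenyl at this place gives a 7.0-fold lower number from compound 3 to compound 4 (0.85 log units; beyond the scatter) and also a 2.9-fold lower number from compound 2 to compound 4 (0.46 log units; beyond the scatter), so a ring with two chlorines outperforms both the 3-nitrophenyl and the 3-fluorophenyl rings. Set against the 3-bromophenyl ring, the comparison gives a 1.0-fold higher number from compound 1 to compound 4 (0.01 log units; within the scatter), so these two halogen-bearing rings cannot be told apart here, even though their halogens and substitution patterns both differ. Nothing available explains these differences.

The compounds shown leave open whether one chlorine alone would read like two, and whether the ring pattern or the halogen matters more. They also leave open how a ring carrying an amine or a carboxylic acid would read in this assay.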